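Bromo substitution on the pyridine of compound 1

The source may report more compounds than this note shows. Statements on the series, on what has been measured and on what is new or still open speak of the compounds shown alone.

Measured in a functional assay on HEK293 cells for agonist activity at Neuronal acetylcholine receptor; alpha4/beta2 (Homo sapiens), read by FLIPR and calcium flux; a higher number here means that more compound is needed for the effect, a lower number that less compound is needed:
- compound 1 `c1cncc(N2CCCNCCC2)c1` gives 36.3 nM
- compound 2 `COc1cc(N2CCCNCC2)cnc1Cl` gives 91.2 nM
- compound 3 `c1ccc2ncc(N3CCCNCC3)cc2c1` gives 3630 nM

Compound 1 stands at the lowest number of the three in this assay. Compound 2 sits closest, and its value is beyond the scatter of compound 1; compound 3 sits furthest, with a number well beyond the scatter of compound 1. For the measured compounds named here, no single-change pair among the measured compounds is available, so no measured step can be quoted.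

Compound 4 `Brc1cncc(N2CCCNCCC2)c1` is not yet measured. It differs from compound 1 by bromo in place of hydrogen on an aromatic carbon, two atoms from the ring nitrogen and meta to a group of 8 heavy atoms.

Going by the values given here, with no comparable measured step in the set, the expectation for compound 4 rests on compound 1 alone; the step from compound 1 to compound 4 is expected to be a 1.4-fold higher number from compound 1 to compound 4 (0.14 log units; within the scatter), not beyond the scatter. Compound 4 is estimated at 50 nM, with a range from 12 nM to 200 nM.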

Compound 4, half-maximal effective concentration: 182 nM
Estimate against measurement, compound 4: 3.6-fold (0.56 log units) below; the range from low to high includes it.
By their numbers in this assay, from the lowest: compound 1; then compounds 2 and 4 (each within the scatter of the next); then compound 3.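

Bromo in place of hydrogen on this aromatic carbon, two atoms from the ring nitrogen and meta to a group of 8 heavy atoms, is not a neutral change in this assay: the series gives a 5.0-fold higher number from compound 1 to compound 4 (0.70 log units; beyond the scatter) as its first single-change step. At this place, one added heavy atom is enough to move the number beyond the scatter, so the hydrogen of compound 1 gives the lower number of the pair. Nothing in hand accounts for the size of this step.

On these data alone, whether this rise is particular to bromo or extends to other groups on the same carbon stays open, and fluoro, a nitrile or an amine there would test this. Also open, as far as these compounds go, is whether the same step would appear on the core of compound 2.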